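Swapping Pentan-3-yl for Naphthalen-1-yl on the Core

The source may report more compounds than this note shows. Statements on the series, on what has been measured and on what is new or still open speak of the compounds shown alone.

Compound 1 `CCC(CC)c1ccc2c(NCCCNCc3cccc(OC)c3O)ccnc2c1`: 410 nM
Compound 2 `Fc1ccc(Cc2ccc3c(NCCCNCc4ccco4)ccnc3c2)c(Cl)c1`: 5730 nM
Compound 3 `COc1ccc(F)cc1CNCCCNc1ccnc2cc(Cc3ccc(C#N)cc3)ccc12`: 6050 nM

In an ADME assay on HepG2 cells (Homo sapiens) for cytotoxicity, read by luminescence, CellTiter-Glo and ATP content, with a stated time of 72 h (a higher number here means that more compound is needed for the effect, a lower number that less compound is needed), compound 1 stands lowest of the three numbers; compound 2 and compound 3 both lie beyond the usual scatter above it. Compound 4 `COc1cccc(CNCCCNc2ccnc3cc(-c4cccc5ccccc45)ccc23)c1O` has not yet been measured. It differs from compound 1 by naphthalen-1-yl in place of pentan-3-yl on an aromatic carbon. For the measured compounds named here, no step between two measured compounds that differ in one place is available, so the expectation rests only on the change itself and on where compound 1 stands. Going by the values given here, with a larger group entering and no measured step to guide the direction, the step from compound 1 to compound 4 in this assay is expected to be small, a 1.0-fold lower number from compound 1 to compound 4 (0.01 log units; within the scatter), with no clear direction beyond the scatter. Compound 4 is therefore expected to give about 400 nM, within a range from 150 nM to 1200 nM.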

Compound 4, half-maximal effective concentration: 2520 nM
Compound 4: the middle estimate sits 6.3-fold (0.80 log units) below what was measured; measured number above the stated range.
By their numbers in this assay, from the lowest: compound 1; then compound 4; then compounds 2 and 3 (each within the scatter of the next).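

This place on the shared core does respond to the group it carries: in this assay, naphthalen-1-yl in place of pentan-3-yl gives a 6.1-fold higher number from compound 1 to compound 4 (0.79 log units; beyond the scatter) and so more compound is needed for the effect. The earlier compounds shown here could not show this, since none of them formed a pair differing in one place. Nothing measured here explains the rise.

Still open, as far as these compounds go, is where a single phenyl ring or a shorter chain such as isopropyl would fall at this place. Also open, from the compounds shown here alone, is whether a morpholine there would give a number nearer compound 1 or compound 4.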